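Replacing acetyl with dimethylamino on a pyrazole anticancer scaffold

This account rests on a few compounds, and the source may have more. Where it says the series, first, only, none or still open, it means among the compounds named here.

Of the compounds shown here, two have been tested so far in a functional assay on UO-31 cells (Homo sapiens) for inhibition, read by sulforhodamine B assay, with a stated time of 48 h; a lower number here means a stronger inhibitor of growth, a higher number a weaker inhibitor of growth. Compound 1 `COc1cc(C)cc(-c2c(-c3ccnc(-c4ccc(C(C)=O)cc4)c3)cnn2CC#N)c1` gives 2610 nM in this assay, the lowest of the two numbers recorded. Compound 2 `Cc1cc(O)cc(-c2nn(CC#N)cc2-c2ccnc(-c3ccc(N(C)C)cc3)c2)c1` gives 3230 nM in this assay, and the two values lie within the usual scatter of each other, so neither can be called the stronger inhibitor.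

Compound 3 `COc1cc(C)cc(-c2c(-c3ccnc(-c4ccc(N(C)C)cc4)c3)cnn2CC#N)c1` has not yet been measured in this assay. It differs from compound 1 in one place: dimethylamino in place of acetyl on an aromatic carbon, or, cut one bond further out, 4-acetylphenyl to 4-(dimethylamino)phenyl. Going by the values given here, no measured pair isolates this change. Compound 2 does carry dimethylamino at that position but also differs elsewhere, so the value of compound 2, 3230 nM, only indicates that a dimethylamino-bearing analogue falls in the same range as compound 1.

On that basis the step of a 1.1-fold higher number from compound 1 to compound 3 (0.06 log units; within the scatter) is expected to stay within the scatter, with compound 3 estimated at 3000 nM in this assay, between 1300 nM and 7000 nM.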

Compound 3, concentration for 50% growth inhibition: 508 nM
For compound 3 the middle estimate is 5.9-fold (0.77 log units) above the measured one, and the stated range ends above it.
By their numbers in this assay, from the lowest: compound 3; then compounds 1 and 2 (each within the scatter of the next).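

In this assay, the change of acetyl to dimethylamino on an aromatic carbon, para to a large group, gives a 5.1-fold lower number from compound 1 to compound 3 (0.71 log units; beyond the scatter), which shows that the group at this position can shift the growth-inhibition number beyond the scatter on the core of compound 1; the two earlier compounds differ in more than one place and could not show this. The step comes with no change in heavy-atom count, ring count, or the counts of hydrogen-bond donors and acceptors, as both groups have the same tallies of these; what differs in the counts is a nitrogen in place of an oxygen and the loss of the double bond outside the aromatic rings. Nothing measured here accounts for the size of this step.

Going by these compounds, it remains open whether a primary amine, a morpholine ring or a carboxylic acid at this position would give a number nearer to compound 3 or to compound 1. It is equally open whether the same exchange would give a similar step on the core of compound 2, which has no partner carrying acetyl among the compounds shown.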